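Swapping the ring on an amide nitrogen

A few compounds are considered here, and "the series" means these few. Any claim that something is new, unique, unknown or untested is made for them only; others in the source may bear on it.

Within the data shown here, in a functional assay on KYSE-70 cells for antiproliferative activity against KYSE-70 cell line (Homo sapiens), read by MTT assay, with a stated time of 72 h (a higher number here means a weaker inhibitor, a lower number a stronger inhibitor), compound 2 `O=C(Nc1ccccn1)c1cc(=O)[nH]c2cc(Br)ccc12` gives 11000 nM, the only true number among the three compounds tested so far. Compound 1 `O=C(c1cc(=O)[nH]c2cc(Br)ccc12)N1CCCCC1` reports only a limit, > 20000 nM. Compound 3 `CC(C)(C)c1ccc(NC(=O)c2cc(=O)[nH]c3cc(Br)ccc23)cc1` also reports only a limit, > 20000 nM. Among the measured compounds shown here, the series therefore sits close to a ceiling, (the limit of > 20000 nM in this assay, at which 2 of the 3 values shown sit), and compound 2 is the one compound with a number that can be read below it.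

Compound 4 `O=C(Nc1cccc(Cl)c1)c1cc(=O)[nH]c2cc(Br)ccc12` has not yet been measured. It keeps the shared core and changes one group: 3-chlorophenyl in place of pyridin-2-yl on an amide-type nitrogen.

Little measured evidence bears on this swap. For the measured compounds named here, the one measured step is an at least 1.8-fold lower number from compound 1 to compound 2 (0.25 log units; that floor lies within the scatter), a small change that cannot be told apart from the scatter. Compound 3, whose amide nitrogen also carries a carbon-only ring, offers a second hint with its limit of > 20000 nM, which shows no gain from such a ring. No change beyond the scatter is therefore expected, with a slight lean towards a weaker result, and the expected step is a 1.3-fold higher number from compound 2 to compound 4 (0.10 log units; within the scatter). For compound 4 the estimated value is 14000 nM, with an expected range from 6000 nM to 28000 nM.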

Compound 4, half-maximal inhibitory concentration: > 20000 nM
Compound 4 gave a limit, no number; the forecaster's own chance of this, stated with the estimate: 35%; middle value at least 1.4-fold (0.15 log units) away from the limit.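

Replacing pyridin-2-yl with 3-chlorophenyl on the amide-type nitrogen gives, in this assay, an at least 1.8-fold higher number from compound 2 to compound 4 (0.25 log units; that floor lies within the scatter). The value for compound 4 is a limit and not a number, so this step is only a floor, and that floor alone does not show a real loss of activity, although the true step could be larger. What the result adds is a second ring on this nitrogen that gives no readable number, which leaves compound 2, with its pyridin-2-yl group, as the only one of the four compounds with a true value, while the others share one ceiling: the limit of > 20000 nM in this assay, at which 3 of the 4 values shown sit.

This swap removes the ring nitrogen and adds a chlorine in a single change, so the compounds shown cannot say which of the two matters, or whether either does. A plain phenyl ring on the same amide nitrogen would help to separate the two, and a pyridine ring carrying an amine or a chlorine would show whether the ring nitrogen can give values clearly below that ceiling.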